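This account rests on a few compounds, and the source may have more. Where it says the series, first, only, none or still open, it means among the compounds named here.

Measured compounds:
compound 1, `O=C1[C@@H](NS(=O)(=O)c2ccc(Oc3ccc(Cl)cc3)cc2)CC=CCN1O`, gives 1120 nM in an assay on isolated protein for inhibition of matrix metalloproteinase-9 (Homo sapiens), read by fluorescence, with stated times of 1 h and 15 min; on this read-out higher numbers stand for weaker inhibition and lower numbers for stronger inhibition
compound 2, `O=C1[C@H](NS(=O)(=O)c2ccc(Oc3ccccc3)cc2)CC=CCN1O`, gives 2 nM in this assay
compound 3, `COc1ccc(Oc2ccc(S(=O)(=O)N[C@@H]3CC=CCN(O)C3=O)cc2)cc1`, gives 1 nM in this assay

Compound 2 stands second highest of the three numbers in this assay. Its nearest neighbour is compound 3, which differs from it by a methoxy in place of hydrogen on an aromatic carbon; that step, a 2.0-fold lower number from compound 2 to compound 3 (0.30 log units; within the scatter), stays within the scatter. Among the compounds with values here, the furthest value belongs to compound 1, whose number in this assay is far higher than that of compound 2; no single-change step connects the two, so only the bare values can be compared.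

Compound 4, `O=C1[C@H](NS(=O)(=O)c2ccc(Oc3ccccn3)cc2)CC=CCN1O`, differs from compound 2 by pyridin-2-yl in place of phenyl on an oxygen on an aromatic ring. Within the data shown here, no measured step alters the ring on the oxygen itself; the only step available, from compound 2 to compound 3, changes a substituent on that ring and is within the scatter. For compound 4 a step of a 1.5-fold higher number from compound 2 to compound 4 (0.18 log units; within the scatter) from compound 2 is therefore expected, which is no change beyond the scatter. The estimated value for compound 4 in this assay is 3 nM, with a range from 1 nM to 12 nM.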

Compound 4, half-maximal inhibitory concentration: 23 nM
The estimate for compound 4 lay 7.7-fold (0.88 log units) below the measured number; the measured number lies above the stated range.
By their numbers in this assay, from the lowest: compounds 3 and 2 (each within the scatter of the next); then compound 4; then compound 1.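

Putting pyridin-2-yl in place of phenyl on the oxygen gives a 12-fold higher number from compound 2 to compound 4 (1.06 log units; beyond the scatter) in this assay. Within the data shown here, the earlier methoxy step at this ring stayed within the scatter, so this is the first sign that the position responds, and it does so to a change in the ring itself, which gains one nitrogen and one hydrogen-bond acceptor while keeping its six heavy atoms. The exchange for 4-methoxyphenyl is just as clear, with a 23-fold higher number from compound 3 to compound 4 (1.36 log units; beyond the scatter), and nothing at hand accounts for either step.

From the compounds shown here alone, what pyridin-3-yl or pyridin-4-yl would give on the same oxygen remains open, so the result cannot yet be tied to where the nitrogen sits. Also open, going by these compounds, is whether a methoxy, an amine or a carboxylic acid on the pyridin-2-yl ring would alter the number of compound 4.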